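From 2-Hydroxyethyl to Phenyl on the Sulfur

The compounds below may be only part of what the source reports. "The series", "measured", "known", "first", "only" and "open" are said of these compounds alone.

In a functional assay on Huh-7 cells (Homo sapiens) for cytotoxicity, read by MTT assay, with a stated time of 3 days (a lower number here means that less compound is tolerated, a higher number that more compound is tolerated), compound 1 (`CSCc1ncnc2c1ncn2[C@@H]1O[C@H](CO)[C@@H](O)[C@H]1O`) gives > 100000 nM as a limit of the assay, not a number. Compound 2 (`OCCSCc1ncnc2c1ncn2[C@@H]1O[C@H](CO)[C@@H](O)[C@H]1O`) gives > 100000 nM as a limit as well. Compound 2 therefore has no exact standing, and the data show only the limit of > 100000 nM in this assay, at which 2 of the 2 values shown sit, for the two compounds. Among the compounds with values here, the one measured step, a step that the two limits leave unreadable from compound 1 to compound 2 in this series, offers no size to carry forward.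

Compound 3 (`OC[C@H]1O[C@@H](n2cnc3c(CSc4ccccc4)ncnc32)[C@H](O)[C@@H]1O`) carries phenyl in place of 2-hydroxyethyl on a sulfur, and the change counts as phenyl in place of 2-hydroxyethyl on a sulfur at that one place. Within the data shown here, no measured step involves this exchange, so the data give no direct guide to its size in this assay for this pair. Compound 2 has > 100000 nM as its limit, so any readable number for compound 3 would be expected on the side of less compound tolerated, and another limit remains quite possible. The expected change is an at least 1.4-fold lower number from compound 2 to compound 3 (0.15 log units; that floor lies within the scatter) on this estimate. Compound 3 is estimated at 70000 nM as a middle value, with an expected range from 20000 nM to 100000 nM in this assay.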

Compound 3, half-maximal cytotoxic concentration: > 100000 nM
Compound 3: only a limit was reported (the forecaster's own chance of this, stated with the estimate: 60%); at least 1.4-fold (0.15 log units) between middle value and limit.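

Within the data shown here, compound 3 joins compound 1 and compound 2 in giving only a limit of the assay in this assay, so no step among the three can be read: the limit of > 100000 nM in this assay, at which 3 of the 3 values shown sit.

The compounds shown leave open whether methyl, 2-hydroxyethyl or phenyl on the sulfur makes any difference to the half-maximal cytotoxic concentration, and where each compound's actual value lies.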